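Cytotoxicity check: thiophen-3-yl in place of pyridin-4-yl

The source may report more compounds than this note shows. Statements on the series, on what has been measured and on what is new or still open speak of the compounds shown alone.

Measured so far:
compound 1 `CC(C)N(Cc1cccc(OCCCCCC(=O)O)c1)C(=O)c1ccc(-c2ccncc2)cc1` — > 26000 nM
compound 2 `CC(C)N(Cc1cccc(OCCCCCC(=O)O)c1)C(=O)c1ccc(-c2cccc(Oc3ccccc3)c2)cc1` — > 18700 nM

Both entries are limits, not numbers. For compound 1 the value > 26000 nM is a limit of an ADME assay on Raji cells (Homo sapiens) for cytotoxicity, read by CellTiter-Glo and resazurin assay, with a stated time of 72 h; a lower number here means that less compound is needed, a higher number that more compound is needed for the effect (the limit of > 26000 nM in this assay, at which 1 of the 2 values shown sits). For compound 2 the value > 18700 nM is likewise a limit (the limit of > 18700 nM in this assay, at which 1 of the 2 values shown sits). Compound 1 therefore stands at the edge of what this assay reports, with no number to rank against.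

Compound 3 `CC(C)N(Cc1cccc(OCCCCCC(=O)O)c1)C(=O)c1ccc(-c2ccsc2)cc1` differs from compound 1 by thiophen-3-yl in place of pyridin-4-yl on an aromatic carbon. Among the compounds with values here, no measured step covers such a change; no shift beyond the scatter is expected in this assay in either direction. Compound 3 is estimated at 25000 nM (range 8000 nM to 60000 nM), a step of an at least 1.0-fold lower number from compound 1 to compound 3 (0.01 log units; that floor lies within the scatter), most likely returned again only as a limit.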

Compound 3, half-maximal effective concentration: > 26000 nM
Compound 3 was reported as a limit; the forecaster's own chance of this, stated with the estimate: 80%; middle value at least 1.0-fold (0.01 log units) away from the limit.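

Compound 1 gives only a limit (> 26000 nM). Within the data shown here, compound 3 also gives only a limit (> 26000 nM), so no step between these two compounds can be read. Going by these compounds, whether swapping pyridin-4-yl for thiophen-3-yl changes the cytotoxicity read-out at all remains open.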